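The compounds below may be only part of what the source reports. "The series", "measured", "known", "first", "only" and "open" are said of these compounds alone.

Series of aryl sulfonates with a shared core. Compound 1 `CC(C)(C)C(=O)Nc1ccc(S(=O)(=O)Oc2ccccc2I)cc1` gives 8300 nM in a functional assay on M21 cells (Homo sapiens) for antiproliferative activity, read by sulforhodamine B assay, with a stated time of 48 h; on this read-out lower numbers stand for stronger inhibition and higher numbers for weaker inhibition. Compound 2 `CCNC(=O)Nc1ccc(S(=O)(=O)Oc2ccccc2I)cc1` gives 5600 nM; the step of a 1.5-fold lower number from compound 1 to compound 2 (0.17 log units; within the scatter) is the only one measured, and on the two numbers shown compound 2 and compound 1 lie within the scatter of one another. Compound 3 `O=C(Nc1ccc(S(=O)(=O)Oc2ccccc2I)cc1)NC1CC1` is compound 2 with cyclopropyl in place of ethyl on an amide-type nitrogen. Among the compounds with values here, no measured step touches that nitrogen, so nothing here argues for a change beyond the scatter. The expected step of no change at the digits printed from compound 2 to compound 3 (within the scatter) is therefore small. Compound 3 is estimated at 5600 nM, expected between 2500 nM and 12500 nM.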

Compound 3, half-maximal inhibitory concentration: 11000 nM
Compound 3: the middle estimate sits 2.0-fold (0.29 log units) below what was measured; low and high end bracket the measured number.
By their numbers in this assay, from the lowest: compounds 2, 1 and 3 (each within the scatter of the next).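

In this assay cyclopropyl in place of ethyl on the amide-type nitrogen gives a 2.0-fold higher number from compound 2 to compound 3 (0.29 log units; within the scatter) and so adds a three-membered ring at this place without a step beyond the scatter. Cyclopropylamino in place of tert-butyl on the carbonyl carbon gives a 1.3-fold higher number from compound 1 to compound 3 (0.12 log units; within the scatter) and likewise does not separate these two groups. No measurement on hand offers an explanation for these numbers.

Going by these compounds, whether a longer chain such as n-butyl, or a carboxylic acid, on that nitrogen would move the number beyond the scatter remains open.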